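Changing the aryl group on the triazole nitrogen

A few compounds are considered here, and "the series" means these few. Any claim that something is new, unique, unknown or untested is made for them only; others in the source may bear on it.

Measured so far:
- compound 1 `N#CC1=C(N)Oc2c(c3nc4ccccc4nc3c3ccccc23)C12C(=O)N(Cc1cnnn1-c1ccc(Cl)cc1)c1ccccc12`: > 50000 nM
- compound 2 `Cc1ccc(-n2nncc2CN2C(=O)C3(C(C#N)=C(N)Oc4c3c3nc5ccccc5nc3c3ccccc43)c3ccccc32)cc1Cl`: > 50000 nM
- compound 3 `N#CC1=C(N)Oc2c(N)cc3nc4ccccc4nc3c2C12C(=O)N(Cc1cnnn1-c1ccccc1Br)c1ccccc12`: 29200 nM

In an ADME assay on L02 cells (Homo sapiens) for antiproliferative activity, read by MTT assay, with a stated time of 48 h (on this read-out higher numbers stand for weaker inhibition and lower numbers for stronger inhibition), compound 1 gives only a limit of the assay, > 50000 nM. Compound 2 likewise gives only a limit, > 50000 nM. Among the compounds with values here, compound 3 is the one compound with a number, 29200 nM. The step that the two limits leave unreadable from compound 1 to compound 2 cannot be read, since both ends are limits.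

Compound 4 `CCc1cccc(C)c1-n1nncc1CN1C(=O)C2(C(C#N)=C(N)Oc3c(N)cc4nc5ccccc5nc4c32)c2ccccc21` differs from compound 3 by 2-ethyl-6-methylphenyl in place of 2-bromophenyl on an aromatic nitrogen. Within the data shown here, no measured step touches this position with readable values, so the change is expected to give no step beyond the scatter, an estimated 1.0-fold higher number from compound 3 to compound 4 (0.01 log units; within the scatter). Compound 4 is therefore expected to give about 30000 nM, within 12000 nM to 75000 nM.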

Compound 4, half-maximal inhibitory concentration: > 50000 nM
Compound 4: a limit, no number; the forecaster's own chance of this, stated with the estimate: 35%; at least 1.6-fold (0.22 log units) between middle value and limit.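

Within the data shown here, replacing 2-bromophenyl with 2-ethyl-6-methylphenyl on this aromatic nitrogen gives the first step at this position that can be read at all in this assay: an at least 1.7-fold higher number from compound 3 to compound 4 (0.23 log units; that floor lies within the scatter). As far as these compounds go, this figure is only a floor, so the change cannot be called a real loss of inhibition, and its true size stays unknown. Compound 4 gives only a limit of the assay and joins the other compounds that sit there: the limit of > 50000 nM in this assay, at which 3 of the 4 values shown sit.

From the compounds shown here alone, it remains open whether an unsubstituted phenyl or a 2-methoxyphenyl group in this place would give a measurable number. Also open, going by these compounds, is how a 2-aminophenyl group would compare with the 2-bromophenyl of compound 3.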